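Compound 3 to compound 4: nitro in place of methoxy

The compounds below may be only part of what the source reports. "The series", "measured", "known", "first", "only" and "open" are said of these compounds alone.

In an ADME assay on HeLa cells (Homo sapiens) for cytotoxicity, read by crystal violet staining, with a stated time of 72 h (on this read-out lower numbers stand for higher toxicity in this test and higher numbers for lower toxicity in this test), compound 3 `COc1cc(-c2noc(C(F)(F)F)n2)ccc1OCCCc1cc(C(=O)N(C)C)no1` gives 68000 nM, the highest of the two actual numbers in the series. Compound 2 `CN(C)C(=O)c1cc(CCCOc2ccc(-c3noc(C(F)(F)F)n3)cc2)on1` gives 28000 nM. Compound 1 `CCOC(=O)c1cc(CCCOc2ccc(-c3noc(C(F)(F)F)n3)cc2[N+](=O)[O-])on1` gives > 100000 nM, which is a limit of the assay and not a number.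

Next to be read is compound 4 `CN(C)C(=O)c1cc(CCCOc2ccc(-c3noc(C(F)(F)F)n3)cc2[N+](=O)[O-])on1`. The change is nitro in place of methoxy on an aromatic carbon.

Going by the values given here, one measured step bears directly on this carbon: a 2.4-fold higher number from compound 2 to compound 3 (0.39 log units; beyond the scatter), a modest move on replacing hydrogen with methoxy. Among the compounds with values here, no measured step goes from methoxy to nitro, so the size of this change remains an expectation. Within the data shown here, compound 1 is the only measured compound with nitro, and it has no measured partner differing only at that carbon, so it supplies no step size. Its reading does suggest that nitro need not bring the number down in this assay. No clear move in either direction is therefore expected.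

The expected change is a 1.0-fold lower number from compound 3 to compound 4 (0.02 log units; within the scatter), estimated to lie within the scatter. Compound 4 may also reach (the limit of > 100000 nM in this assay, at which 1 of the 3 values shown sits), so a report of a limit alone is possible. For compound 4 the estimate is 65000 nM, with an expected range of 30000 nM to 100000 nM.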

Compound 4, half-maximal cytotoxic concentration: 22500 nM
Compound 4: the middle estimate sits 2.9-fold (0.46 log units) above what was measured, and the stated range ends above it.
By their numbers in this assay, from the lowest: compounds 4 and 2 (each within the scatter of the next); then compound 3. At a limit, above all of these: compound 1.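

In this assay, methoxy and nitro on this aromatic carbon do not read alike: the change gives a 3.0-fold lower number from compound 3 to compound 4 (0.48 log units; beyond the scatter). Nitro in place of hydrogen gives a 1.2-fold lower number from compound 2 to compound 4 (0.09 log units; within the scatter), so among the dimethylamide compounds only compound 3, with methoxy, stands apart at this carbon, while the nitro and hydrogen compounds read alike. Nitro alone therefore does not account for the reading of compound 1, since dimethylamino in place of ethoxy on the carbonyl carbon gives an at least 4.4-fold lower number from compound 1 to compound 4 (0.64 log units; beyond the scatter), a step that starts from a limit and not from a number: the limit of > 100000 nM in this assay, at which 1 of the 4 values shown sits.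

On these data alone, whether the higher number belongs to methoxy alone or extends to other groups on this aromatic carbon stays open, and a hydroxyl, an ethoxy or an amine there would help to separate the two readings. Also open, as far as these compounds go, is whether the step from the ethyl ester to the dimethylamide holds with hydrogen or methoxy on the aromatic carbon, since only the nitro pair reads it, and how a carboxylic acid at that carbonyl carbon would read.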